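From compound 3 to compound 4: hydrogen for bromo

This account rests on a few compounds, and the source may have more. Where it says the series, first, only, none or still open, it means among the compounds named here.

Of the compounds shown here, three on the shared core have been read so far in a functional assay on HepG2 cells (Homo sapiens) for cytotoxicity, read by MTT assay, with a stated time of 72 h (a lower number here means a stronger inhibitor, a higher number a weaker inhibitor), with mixed results. Compound 1 `COc1cc2ncnc(Nc3ccc(F)c(Cl)c3)c2cc1NC(=O)N/N=C/c1cccc(Br)c1` gives "not active" (no number reported) with no number reported. Compound 2 `COc1cc2ncnc(Nc3ccc(F)c(Cl)c3)c2cc1NC(=O)N/N=C/c1ccc(F)cc1Cl` gives 29200 nM in the same assay. Compound 3 `COc1cc2ncnc(Nc3ccc(F)c(Cl)c3)c2cc1NC(=O)N/N=C/c1ccc(O)c(Br)c1` gives 23800 nM and so stands level with compound 2. Among the compounds with values here, the one measured step, a 1.2-fold lower number from compound 2 to compound 3 (0.09 log units; within the scatter) on exchanging 2-chloro-4-fluorophenyl for 3-bromo-4-hydroxyphenyl, lies within the scatter, and no order can be read between the two.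

Compound 4 `COc1cc2ncnc(Nc3ccc(F)c(Cl)c3)c2cc1NC(=O)N/N=C/c1ccc(O)cc1` remains unmeasured. It carries hydrogen in place of bromo on an aromatic carbon with the change reading 3-bromo-4-hydroxyphenyl to 4-hydroxyphenyl. Within the data shown here, no measured step isolates the bromo alone. The nearest guide is a 1.2-fold lower number from compound 2 to compound 3 (0.09 log units; within the scatter) for a change of the whole group, and that step stays within the scatter. No step beyond the scatter is therefore expected in this assay and the expected step is a 1.1-fold higher number from compound 3 to compound 4 (0.04 log units; within the scatter) as a working figure. A result without a number also remains possible, given that compound 1 gives "not active" (no number reported) in this series. For compound 4 the estimate is 26000 nM with an expected range from 12000 nM to 56000 nM for the coming measurement.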

Compound 4, half-maximal inhibitory concentration: 26300 nM
Estimate against measurement, compound 4: 1.0-fold (0.00 log units) below; the measured number falls inside the stated range.
By their numbers in this assay, from the lowest: compounds 3, 4 and 2 (each within the scatter of the next).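

Taking off the bromo ortho to a hydroxy group is the first change in the series to isolate that atom, and in this assay it gives a 1.1-fold higher number from compound 3 to compound 4 (0.04 log units; within the scatter), so at this position the bromo has no readable effect on the number. The exchange of the whole group, 2-chloro-4-fluorophenyl to 4-hydroxyphenyl, gives a 1.1-fold lower number from compound 2 to compound 4 (0.05 log units; within the scatter), which places compounds 2, 3 and 4 level with no order among them, while compound 1 stands apart from this group with "not active" (no number reported) in this assay. No supporting data bear on why the number stays level when the bromo leaves.

The compounds shown leave open whether any replacement at this position can move the number beyond the scatter, for example an amine or a carboxylic acid in place of the bromo. They also leave open what the hydroxy group itself contributes, since no listed step takes it away on its own, and whether a methoxy group in its place would keep a numerical reading in this series.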